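This account rests on a few compounds, and the source may have more. Where it says the series, first, only, none or still open, it means among the compounds named here.

Measured so far in a functional assay on Bel-7402 cells (Homo sapiens) for cytotoxicity, read by resazurin assay, with a stated time of 72 h; on this read-out lower numbers stand for stronger inhibition and higher numbers for weaker inhibition:
- compound 1 `N#CCCSC(=S)NCc1cccnc1` gives 1030 nM
- compound 2 `OCCCSC(=S)NCc1cccnc1` gives 3650 nM
- compound 3 `O=C(O)CCSC(=S)NCc1cccnc1` gives 7420 nM

Among these three, compound 3 has the highest number, and its steps to the other two are beyond the scatter. Compound 4 `NC(=O)CCSC(=S)NCc1cccnc1` keeps everything in compound 3 except for amino in place of hydroxy on a carbonyl carbon, which reads as carboxy to carbamoyl.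

Among the measured compounds shown here, no carbamoyl compound has been measured, so only two steps bear on this change, both with carboxy entering on the same chain. They are a 7.2-fold higher number from compound 1 to compound 3 (0.86 log units; beyond the scatter) and a 2.0-fold higher number from compound 2 to compound 3 (0.31 log units; beyond the scatter), and both are modest. Read in reverse, they suggest that losing the carboxy should lower the number in this assay, though only modestly. The expected move is a 2.5-fold lower number from compound 3 to compound 4 (0.39 log units; beyond the scatter) and remains an estimate. For compound 4 the estimated value is 3000 nM, with an expected range of 1100 nM to 7500 nM.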

Compound 4, half-maximal inhibitory concentration: 3330 nM
Beside the measured number, compound 4's estimate is 1.1-fold (0.05 log units) below it; the measured number falls inside the stated range.
By their numbers in this assay, from the lowest: compound 1; then compounds 4 and 2 (each within the scatter of the next); then compound 3.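

In this assay, amino in place of hydroxy on the carbonyl carbon gives a 2.2-fold lower number from compound 3 to compound 4 (0.35 log units; beyond the scatter), so the carbonyl can stay while the carboxy goes and the number still drops. Carbamoyl and hydroxymethyl at this chain end cannot be told apart, with a 1.1-fold lower number from compound 2 to compound 4 (0.04 log units; within the scatter), so these two groups read alike here despite the carbonyl that only carbamoyl carries. The cyano end of compound 1 remains separate from carbamoyl, with a 3.2-fold higher number from compound 1 to compound 4 (0.51 log units; beyond the scatter), which leaves compound 1 with the lowest number of the four.

Nothing at hand gives a reason for this order. Going by these compounds, how a methyl ester or an amine at this chain end would read stays open, as does whether a longer chain would preserve the order seen here.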